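A few compounds are considered here, and "the series" means these few. Any claim that something is new, unique, unknown or untested is made for them only; others in the source may bear on it.

In a functional assay on U-373MG ATCC cells (Homo sapiens) for inhibition, read by MTT assay, with a stated time of 72 h (on this read-out lower numbers stand for stronger inhibition and higher numbers for weaker inhibition), compound 1 `CC1(C)CC(NC(=O)Nc2cccc(Cl)c2)c2cc(Br)ccc2O1` gives 69000 nM and compound 2 `CC1(C)CC(NC(=O)Nc2ccccc2Cl)c2cc(F)ccc2O1` gives 40000 nM while compound 3 `CC1(C)CC(NC(=O)Nc2ccccc2)c2cc(Cl)ccc2O1` gives 68000 nM and so stands within the scatter of both of the others. The next entry is compound 4 `CC1(C)CC(NC(=O)Nc2ccccc2Cl)c2cc(Cl)ccc2O1` which differs from compound 3 by chloro in place of hydrogen on an aromatic carbon and this turns phenyl into 2-chlorophenyl. Among the compounds with values here, no two measured compounds differ in one place only, so the size of this change has no direct measured precedent. The nearest indirect guide is compound 2 with 40000 nM which already bears the 2-chlorophenyl group and still lies within the scatter of compound 3. On that basis no shift beyond the scatter is expected in this assay and the estimated 1.4-fold lower number from compound 3 to compound 4 (0.13 log units; within the scatter) is small, with a direction that the data do not settle firmly. The expected value for compound 4 is 50000 nM with an estimated range of 25000 nM to 100000 nM in this series.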

Compound 4, half-maximal inhibitory concentration: 17000 nM
Compound 4: middle estimate off by 2.9-fold (0.47 log units), on the high side; measured number outside the range, below it.
By their numbers in this assay, from the lowest: compound 4; then compounds 2, 3 and 1 (each within the scatter of the next).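

In this assay, within the data shown here, the change from phenyl to 2-chlorophenyl gives a 4.0-fold lower number from compound 3 to compound 4 (0.60 log units; beyond the scatter), the first measured single-place step at this position, and it shows that chloro in place of hydrogen on this aromatic carbon moves the number beyond the scatter. With 2-chlorophenyl held fixed, chloro in place of fluoro on an aromatic carbon of the core gives a 2.4-fold lower number from compound 2 to compound 4 (0.37 log units; beyond the scatter), so the halogen on the core also matters in this assay. The compounds shown offer no measurement that bears on the reason for either step.

As far as these compounds go, it remains open whether a methoxy group, an amine or a bromo at the 2-chlorophenyl position would give a similar step. Both steps also end at compound 4, so whether either holds on a different partner in the series is unresolved.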